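A few compounds are considered here, and "the series" means these few. Any claim that something is new, unique, unknown or untested is made for them only; others in the source may bear on it.

Among the compounds with values here, in a functional assay on HCT-116 cells (Homo sapiens) for cytotoxicity, read by MTT assay, with a stated time of 72 h (a lower number here means a stronger inhibitor, a higher number a weaker inhibitor), the three compounds measured so far give no numbers, only limits. Compound 1 (`CS(=O)(=O)Oc1c(C(=O)NCc2ccc(F)cc2)nc(Br)c2cccnc12`) is recorded as the limit > 20000 nM. Compound 2 (`O=C(NCc1ccc(F)cc1)c1nc(Br)c2cccnc2c1NCCO`) is likewise recorded as the limit > 20000 nM. Compound 3 (`C[C@H](Nc1c(C(=O)NCc2ccc(F)cc2)nc(Br)c2cccnc12)c1ccccc1`) also gives only a limit, > 20000 nM. Compound 3 thus stands with the others, and the whole set amounts to the limit of > 20000 nM in this assay, at which 3 of the 3 values shown sit.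

Compound 4 (`NCCNc1c(C(=O)NCc2ccc(F)cc2)nc(Br)c2cccnc12`) carries 2-aminoethyl in place of 1-phenylethyl on a nitrogen on an aromatic ring. The closest measured change is a step that the two limits leave unreadable from compound 2 to compound 3, made at the same place. The others, a step that the two limits leave unreadable from compound 1 to compound 2 and a step that the two limits leave unreadable from compound 1 to compound 3, offer no size either. Within the data shown here, no measured step therefore supports a large change, and any shift is tentatively expected towards a stronger inhibitor. The expected change is an at least 1.3-fold lower number from compound 3 to compound 4 (0.12 log units; that floor lies within the scatter). In this assay, compound 4 is estimated at 15000 nM, with an expected range from 4000 nM to 40000 nM, and another limit is quite likely.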

Compound 4, half-maximal inhibitory concentration: > 20000 nM
Compound 4 was reported as a limit; the forecaster's own chance of this, stated with the estimate: 60%; at least 1.3-fold (0.12 log units) between middle value and limit.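

Compound 4, like compounds 1, 2 and 3, is recorded only as a limit, so none of the steps among these four compounds can be read in this assay: the limit of > 20000 nM in this assay, at which 4 of the 4 values shown sit.

The compounds shown leave open whether any group at this place on the shared core gives a measurable value in this assay, and how far apart the four compounds truly lie.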